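A few compounds are considered here, and "the series" means these few. Any claim that something is new, unique, unknown or untested is made for them only; others in the source may bear on it.

Of the compounds shown here, three built on one shared core have been measured in a functional assay on HCT-116 cells (Homo sapiens) for cytotoxicity, read by MTT assay, with a stated time of 48 h; a higher number here means a weaker inhibitor, a lower number a stronger inhibitor. Compound 1 `O=C(/C=C/c1ccc2c(c1)B(O)OC2)c1ccco1` gives 24100 nM in this assay. Compound 2 `O=C(/C=C/c1ccc2c(c1)B(O)OC2)c1cccs1` gives 14200 nM. Compound 3 `O=C(/C=C/c1ccc2c(c1)B(O)OC2)c1ccc(I)cc1` gives 11600 nM, the lowest of the three numbers; the step of a 1.2-fold lower number from compound 2 to compound 3 (0.09 log units; within the scatter) lies within the scatter, while the step of a 2.1-fold lower number from compound 1 to compound 3 (0.32 log units; beyond the scatter) lies beyond it. The step of a 1.7-fold lower number from compound 1 to compound 2 (0.23 log units; within the scatter) also stays within the scatter. Compound 4 `Cc1ccc(C(=O)/C=C/c2ccc3c(c2)B(O)OC3)cc1` differs from compound 3 by methyl in place of iodo on an aromatic carbon, a methyl in place of iodo on an aromatic carbon of a six-membered aromatic ring of carbon only, para to a large group. Within the data shown here, none of the measured steps touches this position: each of them swaps the whole ring on the carbonyl carbon, and all three of those swaps gave only small movements. Among the measured compounds shown here, with no measured step bearing directly on this change and the whole set lying close together, the step of a 1.2-fold higher number from compound 3 to compound 4 (0.08 log units; within the scatter) is expected to stay within the scatter. Compound 4 is therefore estimated at 14000 nM, with a range from 7000 nM to 30000 nM.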

Compound 4, half-maximal inhibitory concentration: 10500 nM
Estimate against measurement, compound 4: 1.3-fold (0.12 log units) above; the measured number falls inside the stated range.
By their numbers in this assay, from the lowest: compounds 4, 3, 2 and 1 (each within the scatter of the next, the first and the last beyond it).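

On the six-membered aromatic ring, para to a large group, methyl in place of iodo is the first change shown that leaves the rest of the ring intact, and in this assay this step stays within the scatter (a 1.1-fold lower number from compound 3 to compound 4 (0.04 log units; within the scatter)). The 4-methylphenyl group also stays within the scatter of thiophen-2-yl (a 1.4-fold lower number from compound 2 to compound 4 (0.13 log units; within the scatter)), while its step from furan-2-yl lies beyond the scatter (a 2.3-fold lower number from compound 1 to compound 4 (0.36 log units; beyond the scatter)), as the step to 4-iodophenyl does. Nothing available explains why iodo and methyl give numbers so close together.

The compounds shown leave open what an amine, a carboxylic acid or a longer chain would do in this place. They also leave open whether any group here could move the number beyond the scatter from compound 3.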